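A Ring Gives Way to an Open Chain

The source may report more compounds than this note shows. Statements on the series, on what has been measured and on what is new or still open speak of the compounds shown alone.

In an ADME assay on CEM-SS cells (Homo sapiens) for cytotoxicity, read by XTT assay, with a stated time of 6 days (a lower number here means that less compound is tolerated, a higher number that more compound is tolerated), compound 1 `CCCC(=O)OCSc1ccccc1C(=O)NCC(N)=O` gives > 100 uM, which is a limit and not a number. Compound 2 `CCCC(=O)OCSc1ccccc1C(=O)NCCCC(N)=O` gives 56.6 uM and compound 3 `CCCC(=O)OCSc1ccccc1C(=O)N[C@@H]1CCC[C@H]1C(N)=O` gives 43.7 uM. These two values stand level, as a 1.3-fold lower number from compound 2 to compound 3 (0.11 log units; within the scatter) shows.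

Compound 4 `CCCC(=O)OCSc1ccccc1C(=O)NCC(=O)N(C)C` has not yet been measured. It carries (dimethylcarbamoyl)methyl in place of 2-carbamoylcyclopentyl on an amide-type nitrogen.

The most relevant measurement is the opposite change, carbamoylmethyl giving way to 2-carbamoylcyclopentyl, which produced an at least 2.2-fold lower number from compound 1 to compound 3 (0.35 log units; beyond the scatter). The other relevant change, 2-carbamoylethyl in place of carbamoyl, produced an at least 1.7-fold lower number from compound 1 to compound 2 (0.24 log units; that floor lies within the scatter). Both sizes are floors, not exact steps. For the measured compounds named here, no measured step covers the dimethylcarbamoyl end of the new group, so only part of the first step is safely reversed. A modest rise is therefore expected, meaning that more compound should be tolerated. The expected change is a 1.8-fold higher number from compound 3 to compound 4 (0.26 log units; within the scatter). For compound 4 the estimated value is 80 uM, with an expected range from 40 uM to 150 uM.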

Compound 4, half-maximal toxic concentration: 38.3 uM
The estimate for compound 4 lay 2.1-fold (0.32 log units) above the measured number, and the stated range ends above it.
By their numbers in this assay, from the lowest: compounds 4, 3 and 2 (each within the scatter of the next). At a limit, above all of these: compound 1.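

In this assay, swapping the ring for the open chain on the amide-type nitrogen gives no readable change (a 1.1-fold lower number from compound 3 to compound 4 (0.06 log units; within the scatter)), and compound 4 also stands level with the longer open chain of compound 2 (a 1.5-fold lower number from compound 2 to compound 4 (0.17 log units; within the scatter)), so an open chain alone does not set the number apart from a ring here. What is new is that a change at the far end of the short chain is enough to shift the number: dimethylamino in place of amino on a carbonyl carbon gives an at least 2.6-fold lower number from compound 1 to compound 4 (0.41 log units; beyond the scatter). The value of compound 1 is a limit and not a number, so that step is only a floor: the limit of > 100 uM in this assay, at which 1 of the 4 values shown sits.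

The compounds shown leave open how a single methylamino group on that carbonyl carbon would read, and whether the number would follow with a carboxylic acid there. They also leave open how the 2-carbamoylcyclopentyl ring would read with dimethylamino on its carbonyl carbon.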